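Methyl on the phenyl of compound 1: stability expectation

A few compounds are considered here, and "the series" means these few. Any claim that something is new, unique, unknown or untested is made for them only; others in the source may bear on it.

compound 1 `C[C@H](Nc1nc(N)nc(N)c1C#N)c1cc2ccc(F)cn2c(=O)c1-c1ccccc1` 88%
compound 2 `Cc1nc(N)c(C#N)c(N[C@@H](C)c2cc3ccc(F)cn3c(=O)c2-c2ccccc2)n1` "not determined" (no result reported)
compound 3 `Cc1nc(N)nc(N[C@@H](C)c2cc3ccc(F)cn3c(=O)c2-c2ccccc2)c1C#N` 41%

In an ADME assay on microsomes from liver (Rattus norvegicus), read by LC-MS, using NADPH, with a stated time of 30 min, tested at 1 uM (a lower number here means that less of the compound is left, a higher number that more of the compound is left), compound 1 gives 88%, the highest of the two numbers at hand; compound 3 sits a number 47 percentage points lower from compound 1 to compound 3 (beyond the scatter) below it, and compound 2 gives "not determined" (no result reported) in this assay. Compound 4 `Cc1cccc(-c2c([C@H](C)Nc3nc(N)nc(N)c3C#N)cc3ccc(F)cn3c2=O)c1` is the next one to be read. It differs from compound 1 by methyl in place of hydrogen on an aromatic carbon; cut one bond further out, the change reads phenyl to 3-methylphenyl.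

Within the data shown here, the only measured step, methyl in place of amino on an aromatic carbon of the shared core, which was a number 47 percentage points lower from compound 1 to compound 3 (beyond the scatter), touches a different part of the molecule and does not bear directly on a methyl added to the phenyl. Among the measured compounds shown here, no step for a change on the phenyl has been measured, so there is no direct precedent for the size of the effect. With compound 1 already high in this assay, the expectation is a step of a number 10 percentage points lower from compound 1 to compound 4 (within the scatter), which is estimated to stay close to compound 1. Compound 4 is therefore estimated at 78%, with a range from 55% to 95%, before the actual value is known.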

Compound 4, percent of the compound remaining: 77%
Compound 4: the middle estimate sits 1 percentage points above what was measured; the measured number falls inside the stated range.
By their numbers in this assay, from the lowest: compound 3; then compound 4; then compound 1.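

In this assay, among these compounds, the change from phenyl to 3-methylphenyl gives a number 11 percentage points lower from compound 1 to compound 4 (beyond the scatter), the first reading for a substituent on this ring. A single added methyl here therefore has an effect beyond the scatter, yet the step is smaller than the one on the shared core, a number 47 percentage points lower from compound 1 to compound 3 (beyond the scatter), and compound 4 still reads 77%. No measurement at hand accounts for the difference between compound 1 and compound 4.

The compounds shown leave open whether a methyl elsewhere on the phenyl would give a step of similar size, and whether a methoxy group, a chlorine atom or a trifluoromethyl group in this same place would track the methyl. They also leave open whether the same phenyl change would give a similar step on the core of compound 3.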